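This account rests on a few compounds, and the source may have more. Where it says the series, first, only, none or still open, it means among the compounds named here.

Measured compounds: compound 1 `NC(=O)Cc1cc(=O)oc2cc(OCc3ccccc3)ccc12`, which in an assay for inhibition of Amine oxidase [flavin-containing] B (Rattus norvegicus) (a lower number here means a stronger inhibitor, a higher number a weaker inhibitor), gives 200 nM, and compound 2 `CC(C(N)=O)c1cc(=O)oc2cc(OCc3ccccc3)ccc12`, which in this assay gives 100 nM.

Compound 2 holds the lower of the two numbers; its nearest comparison is compound 1, and the step of a 2.0-fold lower number from compound 1 to compound 2 (0.30 log units; within the scatter) lies within the scatter. Compound 3 `CN(C)C(=O)Cc1cc(=O)oc2cc(OCc3ccccc3)ccc12` differs from compound 2 by (dimethylcarbamoyl)methyl in place of 1-carbamoylethyl on an aromatic carbon. For the measured compounds named here, only that one measured step bears on this change, and it covers just the methyl on the chain carbon; nothing measured speaks to the dimethylated amide nitrogen. No step beyond the scatter is therefore expected, the estimated step being a 2.0-fold higher number from compound 2 to compound 3 (0.30 log units; within the scatter). Compound 3 is expected at 200 nM in this assay, between 60 nM and 700 nM.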

Compound 3, half-maximal inhibitory concentration: 400 nM
Compound 3: middle estimate off by 2.0-fold (0.30 log units), on the low side; the measured number falls inside the stated range.
By their numbers in this assay, from the lowest: compounds 2, 1 and 3 (each within the scatter of the next, the first and the last beyond it).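

The step of a 2.0-fold higher number from compound 1 to compound 3 (0.30 log units; within the scatter) for dimethylamino in place of amino on a carbonyl carbon shows that this change alone does not separate the two amides in this assay. For the compounds shown here, the step of a 4.0-fold higher number from compound 2 to compound 3 (0.60 log units; beyond the scatter) for (dimethylcarbamoyl)methyl in place of 1-carbamoylethyl is modest, but it is the first here to pass beyond the scatter. Nothing available accounts for that step.

Open, on these data alone, is how an N-methyl amide, a carboxylic acid or an amine would read on this aromatic carbon. Also open, as far as these compounds go, is what a longer chain would do there.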